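This account rests on a few compounds, and the source may have more. Where it says the series, first, only, none or still open, it means among the compounds named here.

Measured so far in a functional assay on A549 cells (Homo sapiens) for cytotoxicity, with a stated time of 60 h; on this read-out higher numbers stand for an effect only at larger amounts of compound and lower numbers for an effect already at smaller amounts:
- Compound 1 `CCN(CC)C(=O)c1c(NCc2cccs2)sc2c1CCCC2`: > 30000 nM, a limit of the assay
- Compound 2 `CCN(CC)C(=O)c1c(NC(=O)c2cccs2)sc2c1CC(C)CC2`: 1000 nM

Compound 1 gives > 30000 nM, which is a limit and not a number. For the measured compounds named here, compound 2, at 1000 nM, therefore holds the only true number so far, and it offers a single point of reference rather than a trend. The two compounds differ in more than one place, so their values cannot be tied to any one structural change.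

Compound 3 `CCN(CC)C(=O)c1c(NC(=O)c2cccs2)sc2c1CC(C)(C)CC2` departs from compound 2 in a single place: methyl in place of hydrogen on a saturated ring carbon. In words, a methyl takes the place of a hydrogen on a saturated ring carbon. Going by the values given here, no measured pair shows what such a change does in this assay, so any forecast stays uncertain. With compound 2 at 1000 nM as the only anchor and just this small change, no shift beyond the usual scatter is expected, in either direction. The expected step of no change at the digits printed from compound 2 to compound 3 (within the scatter) is accordingly small. For compound 3 the estimated value is 1000 nM, with an expected range from 350 nM to 3500 nM.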

Compound 3, half-maximal effective concentration: 6000 nM
The estimate for compound 3 lay 6.0-fold (0.78 log units) below the measured number; measured number outside the range, above it.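

For the compounds shown here, this is the first pair that differs in one place only, so a change in this assay can now be tied to a single group: methyl in place of hydrogen on a saturated ring carbon (a 6.0-fold higher number from compound 2 to compound 3 (0.78 log units; beyond the scatter)). As a higher number here means an effect only at larger amounts of compound, this position is not indifferent to even one added carbon, and a larger amount of compound 3 is needed for the effect. Compound 3 still gives a true number, so the full size of the step can be read, although the assay does have a limit that can hide the size of a step: the limit of > 30000 nM in this assay, at which 1 of the 3 values shown sits.

What lies behind this step stays open, as one pair gives a single point and no reason for the shift. No ethyl, hydroxyl or amine on the same ring carbon has been measured. Such compounds would show whether a higher number appears with other groups as well or only with methyl.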